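Arylamine in place of benzylamine on the shared core

A few compounds are considered here, and "the series" means these few. Any claim that something is new, unique, unknown or untested is made for them only; others in the source may bear on it.

Compound 1 `Cc1ccccc1Nc1nc(NCc2ccco2)ncc1Cl`: > 100000 nM
Compound 2 `Cc1ccccc1Nc1nc(Nc2ccc(N3CCCCC3)cn2)ncc1Cl`: 21400 nM
Compound 3 `Cc1ccc(CNc2nc(Nc3ccc(N4CCN(C)CC4)cn3)ncc2Cl)cc1`: 38100 nM

Three compounds share one core and were tested in a functional assay on MCF7 cells (Homo sapiens) for inhibition, read by CCK-8 assay, with a stated time of 48 h; a higher number here means a weaker inhibitor of growth, a lower number a stronger inhibitor of growth. For compound 1 the assay reports only a limit, > 100000 nM. Compound 2 gives 21400 nM and compound 3 gives 38100 nM, so compound 3 carries the larger of the two numbers, yet the gap to compound 2 lies within the usual scatter. Compound 4 `COc1cccc(Nc2nc(Nc3ccc(N4CCN(C)CC4)cn3)ncc2Cl)c1` is not yet measured. It differs from compound 3 in one place: 3-methoxyphenyl in place of 4-methylbenzyl on a nitrogen on an aromatic ring. Compound 2 shows that an arylamine at that nitrogen is compatible with a measurable number, so a modest move toward a lower number is expected, a 2.1-fold lower number from compound 3 to compound 4 (0.33 log units; beyond the scatter), of a size barely beyond the scatter. Compound 4 is thus estimated at 18000 nM, between 6000 nM and 55000 nM.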

Compound 4, concentration for 50% growth inhibition: 7540 nM
Beside the measured number, compound 4's estimate is 2.4-fold (0.38 log units) above it; the measured number falls inside the stated range.
By their numbers in this assay, from the lowest: compound 4; then compounds 2 and 3 (each within the scatter of the next). At a limit, above all of these: compound 1.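

Changing (4-methylbenzyl)amino to (3-methoxyphenyl)amino on the shared core gives a 5.1-fold lower number from compound 3 to compound 4 (0.70 log units; beyond the scatter) in this assay. This is the only step shown at this nitrogen that can be read directly, and it places an arylamine below a benzylamine when the rest of the molecule is held constant. Nothing measured here accounts for the size of this step.

As far as these compounds go, it remains open whether the step follows the methoxy group or the direct attachment of the ring to the nitrogen. A plain phenyl or a 3-methoxybenzyl group at this nitrogen would separate the two.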